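Swapping a pyridine for a fluorophenyl in a weakly cytotoxic series

The source may hold more compounds than are shown below. What is called first, only, known or untested is meant among the compounds shown, and "the series" means these compounds.

Compound 1 `O[C@@H](c1ccccc1)[C@H]1CO[C@H](c2ccccc2)[C@@H](C/C=C/c2ccncc2)C1`: > 100000 nM
Compound 2 `COc1ccc([C@H]2OC[C@H]([C@@H](O)c3ccc(OC)c(OC)c3)C[C@@H]2C/C=C/c2ccccc2)cc1OC`: 14800 nM
Compound 3 `COc1ccc(/C=C/C[C@@H]2C[C@@H]([C@@H](OC)c3ccc(OC)c(OC)c3)CO[C@H]2c2ccc(OC)c(OC)c2)cc1OC`: > 100000 nM

Of the compounds shown here, three share the core of compound 1 and have been tested in a functional assay on HeLa cells (Homo sapiens) for cytotoxicity, read by WST assay, with a stated time of 48 h; on this read-out higher numbers stand for weaker inhibition and lower numbers for stronger inhibition. In this assay compound 1 reaches only a limit, > 100000 nM, and no number. Compound 3 also sits at a limit, > 100000 nM. Only compound 2 gives a number in this assay, 14800 nM, so compound 1 stands with the weaker pair of the three, at the limit of > 100000 nM in this assay, at which 2 of the 3 values shown sit.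

The next compound, compound 4 `O[C@@H](c1ccccc1)[C@H]1CO[C@H](c2ccccc2)[C@@H](C/C=C/c2cccc(F)c2)C1`, has not yet been measured. It differs from compound 1 in one place: 3-fluorophenyl in place of pyridin-4-yl on a double-bonded chain carbon bound to a double-bonded chain carbon. Among the measured compounds shown here, no step between two measured compounds shows what this change does in this assay, so the expectation rests on where compound 1 stands. With two of three values at the limit, compound 4 is expected to stay weak, with a step of an at least 1.6-fold lower number from compound 1 to compound 4 (0.22 log units; that floor lies within the scatter) that is more a guess than a measured trend. Compound 4 is therefore estimated at 60000 nM, within a range from 15000 nM to 200000 nM.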

Compound 4, half-maximal inhibitory concentration: 8380 nM
Estimate against measurement, compound 4: 7.2-fold (0.85 log units) above; measured number below the stated range.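

Putting 3-fluorophenyl in place of pyridin-4-yl on a double-bonded chain carbon bound to a double-bonded chain carbon gives, in this assay, an at least 11-fold lower number from compound 1 to compound 4 (1.07 log units; beyond the scatter). Among the compounds shown here, this is the first readable step, and it shows that the aromatic ring at the end of the prop-2-en-1-yl chain is a place where a single change moves the read-out, which the earlier compounds, with no step among them, could not show. The step gives only a floor and not a full size, since compound 1 carries a limit and no number: the limit of > 100000 nM in this assay, at which 2 of the 4 values shown sit.

One step cannot separate losing the ring nitrogen from gaining the fluorine, so a phenyl without fluorine on the core of compound 1 would be the telling comparison. As far as these compounds go, whether a nitrile or an amine in place of the fluorine would hold the gain also stays open.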